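This account rests on a few compounds, and the source may have more. Where it says the series, first, only, none or still open, it means among the compounds named here.

Working notes on the series, read in a functional assay on a cell-free system (plasma, Oryctolagus cuniculus) for inhibition, with stated times of 5 min, 1 min and 6 min; on this read-out higher numbers stand for weaker inhibition and lower numbers for stronger inhibition: compound 1 (`CCOC(=O)c1c(C)nc(-c2ccc(OCC(C)C)c(C#N)c2)n1O`) gives 16800 nM and compound 2 (`CCOC(=O)c1c(C)nc(-c2cccc(C#N)c2)n1OC`) gives 9130 nM. Compound 3 (`CCOC(=O)c1c(C)nc(-c2ccccc2C#N)n1OC`) gives 14900 nM, second highest of the three numbers but within the scatter of both others. Compound 4 (`CCOC(=O)c1c(C)nc(-c2ccccc2)n1OC`) has hydrogen in place of cyano on an aromatic carbon, ortho to a large group: hydrogen in place of cyano on an aromatic carbon. Among the measured compounds shown here, no measured compound lacks the nitrile, so the data give no direct size for this change. With compound 3 at 14900 nM and no separation among the three values, no shift beyond the scatter is expected in this assay, in either direction. The expected step is a 1.2-fold lower number from compound 3 to compound 4 (0.09 log units; within the scatter). For compound 4 the estimated value is 12000 nM, with an expected range of 4500 nM to 30000 nM.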

Compound 4, half-maximal inhibitory concentration: > 30000 nM
Compound 4: only a limit was reported; the forecaster's own chance of this, stated with the estimate: 15%; at least 2.5-fold (0.39 log units) between middle value and limit.
By their numbers in this assay, from the lowest: compounds 2, 3 and 1 (each within the scatter of the next). At a limit, above all of these: compound 4.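

Compound 4, which has hydrogen in place of cyano, reads in this assay only as a limit: the limit of > 30000 nM in this assay, at which 1 of the 4 values shown sits. This is the first compound shown without the nitrile, and the change gives an at least 2.0-fold higher number from compound 3 to compound 4 (0.30 log units; that floor lies within the scatter) and an at least 3.2-fold higher number from compound 2 to compound 4 (0.51 log units; beyond the scatter). Only the second floor clears the scatter, so the nitrile matters to inhibition in this series, though its loss at the carbon ortho to a large group is not separated from the scatter.

From the compounds shown here alone, the full size of either step stays open. Also open, going by these compounds, is whether an amine, a carboxylic acid or a methoxy group on this carbon would read like the nitrile.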